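Working notes on a small allosteric modulator series

The compounds below may be only part of what the source reports. "The series", "measured", "known", "first", "only" and "open" are said of these compounds alone.

Measured in an in vitro functional assay on HEK293-A cells for positive allosteric modulation of metabotropic glutamate receptor 5 (Homo sapiens), read by FLIPR and calcium flux; a lower number here means that less compound is needed, a higher number that more compound is needed for the effect:
Compound 1, `COc1cccc(-c2noc(C3CC(=O)N(c4ccc(Cl)cc4)C3)n2)c1`, gives 4800 nM.
Compound 2, `Cc1cccc(N2CC(c3nc(-c4cccc(Cl)c4)no3)CC2=O)c1`, returns the limit > 10000 nM.
Compound 3, `Cc1cccc(-c2noc(C3CC(=O)N(c4ccc(F)cc4)C3)n2)n1`, returns the limit > 10000 nM.

Compound 3 stands at the upper edge of what is shown: its value in this assay is a limit, not a number, and the limit of > 10000 nM in this assay, at which 2 of the 3 values shown sit, marks the position it shares with compound 2. Only compound 1 gives a measured number. Compound 4, `O=C1CC(c2nc(-c3cccc(F)c3)no2)CN1c1ccc(F)cc1`, differs from compound 3 by 3-fluorophenyl in place of 6-methylpyridin-2-yl on an aromatic carbon. Among the compounds with values here, no measured pair shows this exchange, so its size is open. A phenyl on that carbon is also found in compound 1, which gives 4800 nM rather than a limit. The step expected is an at least 1.2-fold lower number from compound 3 to compound 4 (0.09 log units; that floor lies within the scatter). For compound 4 the estimate in this assay is 8000 nM, from 3000 nM to 20000 nM, with a real chance of only a limit.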

Compound 4, half-maximal effective concentration: 88 nM
Estimate against measurement, compound 4: 91-fold (1.96 log units) above; the measured number lies below the stated range.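

In this assay, within the data shown here, 3-fluorophenyl in place of 6-methylpyridin-2-yl on this aromatic carbon gives an at least 110-fold lower number from compound 3 to compound 4 (2.05 log units; beyond the scatter), the first measured pair to show that this exchange alone can move the series out of the limit and well past the number of compound 1. Compound 3 carries only a limit, so the step gives a floor and not a size: the limit of > 10000 nM in this assay, at which 2 of the 4 values shown sit.

On these data alone, the exchange swaps the ring nitrogen, the methyl and the fluorine together, so which of them carries the step stays open. Also open, as far as these compounds go, is how an unsubstituted phenyl or a nitrile-bearing phenyl would read at this position.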